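A few compounds are considered here, and "the series" means these few. Any claim that something is new, unique, unknown or untested is made for them only; others in the source may bear on it.

Among the measured compounds shown here, compound 2 `CCCCCCCCCCCC[C@@H](O)[C@H]1CC[C@H]([C@H](O)CCCCCCCCCCNCc2ccnn2C)O1` gives 2090 nM in a functional assay on SK-OV-3 cells (Homo sapiens) for inhibition, read by sulforhodamine B assay, with a stated time of 48 h (on this read-out higher numbers stand for weaker inhibition of growth and lower numbers for stronger inhibition of growth), the lower of the two numbers measured so far, while compound 1 `CCCCCCCCCCCC[C@@H](O)[C@H]1CC[C@H]([C@H](O)CCCCCCCCCCNC(=O)c2ccnn2C)O1` gives 100000 nM. The next structure, compound 3 `CCCCCCCCCCCC[C@@H](O)[C@H]1CC[C@H]([C@H](O)CCCCCCCCCCOC(=O)c2ccnn2C)O1`, differs from compound 2 as follows: ((1-methyl-1H-pyrazol-5-yl)carbonyl)oxy in place of ((1-methyl-1H-pyrazol-5-yl)methyl)amino on a saturated chain carbon, ten or more bonds along the chain from an oxygen on a saturated carbon and a saturated ring carbon. Thus ((1-methyl-1H-pyrazol-5-yl)carbonyl)oxy stands in place of ((1-methyl-1H-pyrazol-5-yl)methyl)amino on the saturated chain carbon. For the measured compounds named here, only one measured step bears on this change: a 48-fold lower number from compound 1 to compound 2 (1.68 log units; beyond the scatter), a large step beyond the scatter, in which (1-methyl-1H-pyrazol-5-yl)methyl replaced (1-methyl-1H-pyrazol-5-yl)carbonyl on an amine nitrogen. Going by the values given here, compound 3 keeps a carbonyl, as compound 1 does at 100000 nM, but no measured compound carries the new group, so the expectation remains uncertain. The expected step is a 9.6-fold higher number from compound 2 to compound 3 (0.98 log units; beyond the scatter), towards weaker inhibition of growth in this assay. Compound 3 is estimated at 20000 nM, with an expected range from 4000 nM to 100000 nM.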

Compound 3, concentration for 50% growth inhibition: 100000 nM
For compound 3 the middle estimate is 5.0-fold (0.70 log units) below the measured one; measured number inside the range.
By their numbers in this assay, from the lowest: compound 2; then compounds 1 and 3 (each within the scatter of the next).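

this assay now holds a second large step at this chain end, a 48-fold higher number from compound 2 to compound 3 (1.68 log units; beyond the scatter), which shows that compound 2 is separated from an ester as well as from an amide. Replacing the amide nitrogen with oxygen gives no change at the digits printed from compound 1 to compound 3 (within the scatter), so among these three compounds the two that keep the carbonyl stand together, whichever atom links it to the chain, and only compound 2, which has no carbonyl, stands apart. No measurement at hand explains this difference.

The compounds shown leave open whether the amine nitrogen or the methylene in place of the carbonyl matters more, and an ether linking the same (1-methyl-1H-pyrazol-5-yl)methyl group to the chain would separate the two. They also leave open how an N-methyl tertiary amine or a shorter chain would read here.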